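A few compounds are considered here, and "the series" means these few. Any claim that something is new, unique, unknown or untested is made for them only; others in the source may bear on it.

Within the data shown here, compound 2 `CC(O)(C(=O)Nc1ccc(S(=O)(=O)c2ccccc2Cl)cc1)C(F)(F)F` gives the lower of the two numbers known so far in a functional assay (Cavia porcellus) with sulfonylurea receptors; K-ATP channels (Homo sapiens) as the target (on this read-out lower numbers stand for stronger inhibition and higher numbers for weaker inhibition), namely 2300 nM. Compound 1 `CC(O)(C(=O)Nc1ccc(S(=O)(=O)c2cccc(F)c2)cc1)C(F)(F)F` gives 3400 nM in this assay, and the step of a 1.5-fold lower number from compound 1 to compound 2 (0.17 log units; within the scatter) keeps the two within the scatter, so the two compounds cannot be ranked against each other.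

Compound 3 `CC(O)(C(=O)Nc1ccc(S(=O)(=O)c2cccc(Cl)c2)cc1)C(F)(F)F` has not yet been measured. It differs from compound 2 by 3-chlorophenyl in place of 2-chlorophenyl on a sulfonyl sulfur. Among the measured compounds shown here, only one measured step bears on this kind of change: the step of a 1.5-fold lower number from compound 1 to compound 2 (0.17 log units; within the scatter) swapped one substituted phenyl ring on the sulfonyl sulfur for another, and the number barely moved. Since that sole precedent stayed within the scatter, no step beyond the scatter is expected here either, in neither direction.

Compound 3 is therefore estimated to give about 2800 nM in this assay, with a range from 1000 nM to 8000 nM; the expected step is a 1.2-fold higher number from compound 2 to compound 3 (0.09 log units; within the scatter).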

Compound 3, half-maximal inhibitory concentration: 10000 nM
Compound 3: the middle estimate sits 3.6-fold (0.55 log units) below what was measured, outside the stated range (above it).
By their numbers in this assay, from the lowest: compounds 2 and 1 (each within the scatter of the next); then compound 3.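

In this assay, the step of a 4.3-fold higher number from compound 2 to compound 3 (0.64 log units; beyond the scatter) involves the same atoms joined differently, so whether the ring on the sulfonyl sulfur is 2-chlorophenyl or 3-chlorophenyl clearly matters here. The step of a 2.9-fold higher number from compound 1 to compound 3 (0.47 log units; beyond the scatter) shows that chloro in place of fluoro on an aromatic carbon also matters, whereas the step between compound 1 and compound 2 changed both the halogen and its place and stayed within the scatter, so it could not reveal either effect. No measurement at hand explains either step.

The compounds shown leave open how a methoxy group or a nitrile would compare with chloro and fluoro on this ring. They also leave open where a plain phenyl ring on the sulfonyl sulfur would fall.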